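This account rests on a few compounds, and the source may have more. Where it says the series, first, only, none or still open, it means among the compounds named here.

Compound 1 `CN(C)c1ncnc2c1ncn2Cc1ccccc1N`: 0%
Compound 2 `CN(C)c1ncnc2c1ncn2C1CCCC1`: 27%
Compound 3 `CC(C)N(C)c1ncnc2c1ncn2CC1CC1`: 32%

In a functional assay on the whole organism for inhibition, with Rattus norvegicus as the target, at a dose of 25 mg/kg by the intraperitoneal route (on this read-out lower numbers stand for less inhibition and higher numbers for more inhibition at the one dose given (going by the name of the read-out)), compound 3 gives the highest of the three numbers, yet compound 2 lies within the scatter of it, so the two cannot be ranked; only compound 1 sits clearly lower, beyond the scatter. Compound 4 `CC(C)(C)Nc1ncnc2c1ncn2CC1CC1` differs from compound 3 in one place: (tert-butyl)amino in place of isopropyl(methyl)amino on an aromatic carbon. For the measured compounds named here, no step between measured compounds covers this exchange, so nothing measured says how large its effect is. The account therefore expects a step of a number 4 percentage points lower from compound 3 to compound 4 (within the scatter) from compound 3 to compound 4 that is small, with no direction beyond the scatter. Compound 4 is thus estimated to give 28%, in a range from 5% to 50%.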

Compound 4, a percentage reported as inhibition, in the whole organism at one dose (the size of the read-out at that dose, not a potency): 0%
Estimate against measurement, compound 4: 28 percentage points above; the whole stated range lies above it.
By their numbers in this assay, from the lowest: compounds 1 and 4 (each within the scatter of the next); then compounds 2 and 3 (each within the scatter of the next).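

With the same atoms joined differently, the two amino groups on this aromatic carbon are not interchangeable: in this assay, (tert-butyl)amino in place of isopropyl(methyl)amino gives a number 32 percentage points lower from compound 3 to compound 4 (beyond the scatter). The exchange alters two things at once, as it brings a tert-butyl group and also adds a hydrogen-bond donor, and this single step cannot separate them. Nothing available explains the loss. The compounds shown leave open whether isopropylamino, which keeps the donor without the tert-butyl group, or tert-butyl(methyl)amino, which keeps the tert-butyl group without the donor, would hold the read-out at this position.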